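A few compounds are considered here, and "the series" means these few. Any claim that something is new, unique, unknown or untested is made for them only; others in the source may bear on it.

Compound 1 `CC(C)c1ccccc1-n1cc(COc2cccc(NC(=O)Nc3ccc(Cl)c(C(F)(F)F)c3)c2)nn1` and compound 2 `O=C(Nc1cccc(OCc2cn(-c3cccc(Cl)c3)nn2)c1)Nc1ccc(Cl)c(C(F)(F)F)c1` share one core and differ only in the group on an aromatic nitrogen. In a functional assay on HepG2 cells (Homo sapiens) for inhibition, read by MTT assay, with a stated time of 72 h (a higher number here means a weaker inhibitor, a lower number a stronger inhibitor), compound 1 gives 1900 nM and compound 2 gives 2020 nM; the step of a 1.1-fold higher number from compound 1 to compound 2 (0.03 log units; within the scatter) shows that the two numbers sit within the scatter of each other, so compound 2 has the higher number of the two without standing apart. Compound 3 `O=C(Nc1cccc(OCc2cn(-c3ccc(Br)cc3)nn2)c1)Nc1ccc(Cl)c(C(F)(F)F)c1` carries 4-bromophenyl in place of 3-chlorophenyl on an aromatic nitrogen. For the measured compounds named here, the only measured step that bears on this change, a 1.1-fold higher number from compound 1 to compound 2 (0.03 log units; within the scatter), altered the same group and stayed within the scatter, so no step beyond the scatter is expected in this assay. Compound 3 is therefore expected to give 2000 nM, within 900 nM to 4500 nM. That estimate means an expected step of a 1.0-fold lower number from compound 2 to compound 3 (0.00 log units; within the scatter).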

Compound 3, half-maximal inhibitory concentration: 2730 nM
Beside the measured number, compound 3's estimate is 1.4-fold (0.14 log units) below it, and the stated range covers the measured number.
By their numbers in this assay, from the lowest: compounds 1, 2 and 3 (each within the scatter of the next).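

The step of a 1.4-fold higher number from compound 2 to compound 3 (0.13 log units; within the scatter) and the step of a 1.4-fold higher number from compound 1 to compound 3 (0.16 log units; within the scatter) show that in this assay three differently substituted phenyl groups on this aromatic nitrogen cannot be told apart. The change to 4-bromophenyl alters both the halogen and its place on the ring, so the compounds shown cannot separate these two changes. Nothing measured here gives a reason for these numbers.

The compounds shown leave open whether a group other than a substituted phenyl, such as an amine, a carboxylic acid or a longer carbon chain, would move the number beyond the scatter.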